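From cyclopropylamino to pyrrolidin-1-yl on a shared core

A few compounds are considered here, and "the series" means these few. Any claim that something is new, unique, unknown or untested is made for them only; others in the source may bear on it.

In an ADME assay on CCRF-HSB-2 cells (Homo sapiens) for cytotoxicity, with a stated time of 7 days (a lower number here means that less compound is tolerated, a higher number that more compound is tolerated), compound 3 `Nc1nc(NC2CC2)c2ncn(/C=C3/CC3(CO)CO)c2n1` gives > 20000 nM as a limit, not a number. Compound 1 `COCCOc1nc(N)nc2c1ncn2/C=C1/CC1(CO)CO` gives > 20000 nM as a limit too. Among the compounds with values here, compound 2 `CCCSc1nc(N)nc2c1ncn2/C=C1/CC1(CO)CO` gives 98000 nM as the only true number so far.

Compound 4 `Nc1nc(N2CCCC2)c2ncn(/C=C3/CC3(CO)CO)c2n1` carries pyrrolidin-1-yl in place of cyclopropylamino on an aromatic carbon. Of the measured steps, a step that the two limits leave unreadable from compound 1 to compound 3 and a step that the limit leaves unreadable from compound 2 to compound 3 bear on this change, yet neither has a size to carry over. Within the data shown here, the data offer only the limit of > 20000 nM in this assay, at which 2 of the 3 values shown sit, and the single number of compound 2 at 98000 nM as a guide. The expected size is a step that the limit leaves unreadable from compound 3 to compound 4 with no firm direction. Compound 4 is estimated at 50000 nM within a range of 20000 nM to 120000 nM and may turn out only as a limit.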

Compound 4, half-maximal cytotoxic concentration: > 20000 nM
Compound 4 ended at the assay's limit (the forecaster's own chance of this, stated with the estimate: 65%); the middle value does not contradict the limit.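

No step to compound 4 can be read from compound 1, compound 2 or compound 3, because compound 4 also stops at a limit: the limit of > 20000 nM in this assay, at which 3 of the 4 values shown sit.

The compounds shown leave open whether changing the group on this aromatic carbon shifts the result in this assay at all.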